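Replacing 3-fluorophenyl with 5-bromopyridin-3-yl in compound 1

The source may report more compounds than this note shows. Statements on the series, on what has been measured and on what is new or still open speak of the compounds shown alone.

Compound 1 `Nc1ccccc1NC(=O)c1ccc(NC(=S)NCc2cccc(F)c2)cc1` gives 5900 nM
Compound 2 `Nc1ccccc1NC(=O)c1ccc(CNC(=O)c2cc3cnccc3[nH]2)cc1` gives 4000 nM
Compound 3 `Nc1ccccc1NC(=O)c1ccc(NC(=O)NCc2cccnc2)cc1` gives 9400 nM

In a functional assay on HCT-116 cells (Homo sapiens) for cytotoxicity, read by MTT assay, with a stated time of 72 h (on this read-out higher numbers stand for weaker inhibition and lower numbers for stronger inhibition), compound 1 (5900 nM) lies within the usual scatter of both compound 2 (4000 nM) and compound 3 (9400 nM). Compound 4 (`Nc1ccccc1NC(=O)c1ccc(NC(=S)NCc2cncc(Br)c2)cc1`) has not yet been measured. It carries 5-bromopyridin-3-yl in place of 3-fluorophenyl on a saturated chain carbon bound to an amide-type nitrogen. For the measured compounds named here, no measured pair tests this exchange, so in this assay no step beyond the scatter is expected in either direction. The estimated change is small (a 1.1-fold lower number from compound 1 to compound 4 (0.03 log units; within the scatter)). Compound 4 is expected at 5500 nM (estimated range 2200 nM to 13000 nM).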

Compound 4, half-maximal inhibitory concentration: 9200 nM
For compound 4 the middle estimate is 1.7-fold (0.22 log units) below the measured one; the measured number falls inside the stated range.
By their numbers in this assay, from the lowest: compounds 2, 1, 4 and 3 (each within the scatter of the next, the first and the last beyond it).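

In this assay, for the compounds shown here, this exchange gives the first measured step at this position (a 1.6-fold higher number from compound 1 to compound 4 (0.19 log units; within the scatter)), which stays within the scatter. Compound 4 thus shows that a ring nitrogen and a bromine can enter together in place of 3-fluorophenyl without a step beyond the scatter. No supporting measurement bears on this result. Going by these compounds alone, the single exchange changes both features at once, so their separate contributions cannot be read. On these data alone, whether an amine, a carboxylic acid or a longer chain at this place would shift the number also stays open.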